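The compounds below may be only part of what the source reports. "The series", "measured", "known", "first", "only" and "open" are said of these compounds alone.

Measured compounds in the series:

Compound 1, `CNC(=O)c1cc(Oc2ccc(C(=O)/C=C/c3ccco3)cc2)ccn1`: in a functional assay on MCF7 cells (Homo sapiens) for cytotoxicity, read by MTT assay, with a stated time of 72 h (a higher number here means a weaker inhibitor, a lower number a stronger inhibitor), compound 1 gives "not determined" (no result reported).
Compound 2, `CNC(=O)c1cc(Oc2ccc(C(=O)/C=C/c3cccc(Br)c3)cc2)ccn1`: in this assay compound 2 gives 10400 nM.
Compound 3, `CNC(=O)c1cc(Oc2ccc(C(=O)/C=C/c3ccc([N+](=O)[O-])cc3)cc2)ccn1`: in this assay compound 3 gives "not determined" (no result reported).

Among the measured compounds shown here, compound 2 is the only member with a number; compounds 1 and 3 give nothing to compare it with, so no step between measured compounds is known and compound 2 stands alone as the reference.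

Compound 4, `CNC(=O)c1cc(Oc2ccc(C(=O)/C=C/c3ccccc3)cc2)ccn1`, is not yet measured. It differs from compound 2 as follows: hydrogen in place of bromo on an aromatic carbon. For the measured compounds named here, with no measured step available in this assay, the change from compound 2 to compound 4 is expected to stay within the scatter, with no clear direction. Compound 4 is therefore estimated at 14000 nM, range 5000 nM to 40000 nM, an expected step of a 1.3-fold higher number from compound 2 to compound 4 (0.13 log units; within the scatter).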

Compound 4, half-maximal inhibitory concentration: 5960 nM
Beside the measured number, compound 4's estimate is 2.3-fold (0.37 log units) above it, and the stated range covers the measured number.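

Among the compounds shown here, this is the first readable step. In this assay, hydrogen in place of bromo on the aromatic carbon gives a 1.7-fold lower number from compound 2 to compound 4 (0.24 log units; within the scatter) and stays within the scatter, so the 3-bromophenyl and phenyl ends cannot be told apart here. Bromo at this place is therefore not required for a numeric read-out in this cell assay. Nothing available accounts for this result. Steps involving compounds 1 and 3 cannot be read. As far as these compounds go, whether an amine or a carboxylic acid at this same place would shift the number remains open.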